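Trimming Butyl to Ethyl on a Shared Core

The source may report more compounds than this note shows. Statements on the series, on what has been measured and on what is new or still open speak of the compounds shown alone.

Of the compounds shown here, three built on one shared core have been tested in a functional assay on RAW264.7 cells (Mus musculus) for inhibition, with a stated time of 30 min; a lower number here means a stronger inhibitor, a higher number a weaker inhibitor. Compound 1 `C=C1C(=O)OC[C@H]1CCOC(=O)Nc1ccc(C(=O)OCCCC)cc1` gives 430 nM. Compound 2 `C=C1C(=O)OC[C@H]1CCOC(=O)Nc1ccc(OC)cc1` gives 710 nM. Compound 3 `C=C1C(=O)OC[C@H]1CCOC(=O)Nc1ccc(CCCC)cc1` gives 620 nM. On these numbers compound 3 stands second highest of the three, with compound 2 nearest and compound 1 furthest, and both gaps lie within the scatter, so the three cannot be told apart. Each of the measured steps swaps one group on an aromatic carbon, and none of them moves the number beyond the scatter: a 1.7-fold higher number from compound 1 to compound 2 (0.22 log units; within the scatter), a 1.4-fold higher number from compound 1 to compound 3 (0.16 log units; within the scatter), and a 1.1-fold lower number from compound 2 to compound 3 (0.06 log units; within the scatter).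

Compound 4 `C=C1C(=O)OC[C@H]1CCOC(=O)Nc1ccc(CC)cc1` has not yet been measured. It differs from compound 3 by hydrogen in place of ethyl on a saturated chain carbon, two bonds along the chain from an aromatic carbon. Among the compounds with values here, no measured step shortens a chain in this way; the closest precedent is the exchange of a whole group at the same aromatic carbon, and those exchanges, from a butoxycarbonyl to a methoxy or to a butyl, all stayed within the scatter. The expected step in this assay is therefore small, with no clear direction, amounting to a 1.0-fold higher number from compound 3 to compound 4 (0.02 log units; within the scatter). Compound 4 is estimated at 650 nM, with a range from 300 nM to 1400 nM.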

Compound 4, half-maximal inhibitory concentration: 840 nM
Compound 4: the middle estimate sits 1.3-fold (0.11 log units) below what was measured; low and high end bracket the measured number.
By their numbers in this assay, from the lowest: compounds 1, 3, 2 and 4 (each within the scatter of the next).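

Shortening butyl to ethyl is the first change here made within a chain rather than by exchanging a whole group on the aromatic carbon, and in this assay it gives a 1.4-fold higher number from compound 3 to compound 4 (0.13 log units; within the scatter), so this chain can lose two carbons without a step beyond the scatter. The ethyl compound also stays within the scatter of the other two compounds, with a 1.2-fold higher number from compound 2 to compound 4 (0.07 log units; within the scatter) and a 2.0-fold higher number from compound 1 to compound 4 (0.29 log units; within the scatter); even this last step, the largest among the four compounds, does not separate them, so butoxycarbonyl, methoxy, butyl and ethyl at this place cannot be told apart on these numbers. Nothing available here explains why the numbers stay so close together.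

Going by these compounds, it remains open whether the same flat picture would hold for a carboxylic acid, an amine or a chain longer than butyl on this aromatic carbon. The shared core is identical in all four compounds, so they do not show how the number would respond to a change made there.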